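The compounds below may be only part of what the source reports. "The series", "measured", "known", "first", "only" and "open" are said of these compounds alone.

Measured so far in an in vitro ADME assay on microsomes from liver (Homo sapiens) for metabolic stability; on this read-out higher numbers stand for a longer-lived compound and lower numbers for a shorter-lived compound:
- compound 1 `CC(C)CCN1C(=O)C(C2=NS(=O)(=O)c3cc(NS(C)(=O)=O)ccc3N2)=C(O)[C@H]2CCC[C@H]21`; in this assay compound 1 gives 0.383 h.
- compound 2 `CS(=O)(=O)Nc1ccc2c(c1)S(=O)(=O)N=C(C1=C(O)[C@H]3CCC[C@H]3N(Cc3ccc(F)c(Cl)c3)C1=O)N2`; in this assay compound 2 reaches only an assay limit, > 1 h.

Compound 2 thus stands at the upper edge of the numbers seen, at the limit of > 1 h in this assay, at which 1 of the 2 values shown sits, and its true value is not known beyond that. The step toward compound 3 `CS(=O)(=O)Nc1ccc2c(c1)S(=O)(=O)N=C(C1=C(O)[C@H]3CCC[C@H]3N(Cc3ccc(C(F)(F)F)cc3)C1=O)N2` is 4-(trifluoromethyl)phenyl in place of 3-chloro-4-fluorophenyl on a saturated chain carbon bound to an amide-type nitrogen in a ring. Among the measured compounds shown here, only one measured step bears on this position: an at least 2.6-fold higher number from compound 1 to compound 2 (0.41 log units; beyond the scatter). For the measured compounds named here, that step swapped a saturated chain for an aromatic ring; the present change keeps an aromatic ring and alters only what sits on it, and no measured pair shows such a swap. A step within the scatter of compound 2 is therefore expected in this assay, with no direction favoured, and a further limit read-out is likely. Compound 3 is expected near 1.2 h, between 0.5 h and 3 h. The expected step is a step that the limit leaves unreadable from compound 2 to compound 3.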

Compound 3, half-life: > 1 h
Compound 3: no number, only a limit (the forecaster's own chance of this, stated with the estimate: 55%); the middle value does not contradict the limit.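

In this assay, the place on the saturated chain carbon bound to an amide-type nitrogen in a ring now has two different substituted phenyl groups with limit read-outs, and 4-(trifluoromethyl)phenyl in place of isobutyl gives an at least 2.6-fold higher number from compound 1 to compound 3 (0.41 log units; beyond the scatter). Among the compounds shown here, the higher number is therefore not confined to 3-chloro-4-fluorophenyl, the only aromatic group known at this place before, and it recurs with a group that carries no chlorine. The step between these two aromatic groups cannot be read, so the pair gives no order: the limit of > 1 h in this assay, at which 2 of the 3 values shown sit.

Still open, from the compounds shown here alone, is whether the higher number needs a carbon-only aromatic ring at this place, or would also come with a pyridine ring or a longer saturated chain. Going by these compounds, the true half-lives of compound 2 and compound 3 also remain open.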